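The source may report more compounds than this note shows. Statements on the series, on what has been measured and on what is new or still open speak of the compounds shown alone.

Compound 2 `COc1ccc([C@H]2CC(C)(O)[C@@H]3CC[C@@H](C)C[C@H]3O2)c(OC)c1OC` was tested in an ADME assay on MDCK cells (Canis lupus familiaris) for cytotoxicity, read by MTT assay, with a stated time of 48 h (on this read-out higher numbers stand for lower toxicity in this test and lower numbers for higher toxicity in this test), where compound 2 gives > 857000 nM, a limit of the assay rather than a number. Compound 1 `COc1ccc([C@H]2CC(C)(O)[C@@H]3CC[C@@H](C)C[C@H]3O2)c(OC)c1` likewise gives only a limit in this assay, > 937000 nM. The step that the two limits leave unreadable from compound 1 to compound 2 is accordingly not readable. Compound 3 `COc1ccc([C@H]2CC(C)(F)[C@@H]3CC[C@@H](C)C[C@H]3O2)c(OC)c1OC` differs from compound 2 by fluoro in place of hydroxy on a saturated ring carbon. Going by the values given here, no measured step covers this change, and the two limits the limit of > 857000 nM in this assay, at which 1 of the 2 values shown sits, and the limit of > 937000 nM in this assay, at which 1 of the 2 values shown sits, give no direction. Given the limit of > 937000 nM in this assay, at which 1 of the 2 values shown sits, of compound 2, compound 3 is expected to show no step beyond the scatter, a step that the limit leaves unreadable from compound 2 to compound 3. Compound 3 is estimated at 900000 nM, with a range from 300000 nM to 2000000 nM, most likely again reported as a limit.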

Compound 3, half-maximal cytotoxic concentration: 133000 nM
For compound 3 the middle estimate is 6.8-fold (0.83 log units) above the measured one; measured number outside the range, below it.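

In this assay, fluoro in place of hydroxy on this saturated ring carbon gives an at least 6.4-fold lower number from compound 2 to compound 3 (0.80 log units; beyond the scatter). This is the first readable step among the compounds shown, and it shows that the group on this carbon can shift the read-out towards higher toxicity in this test, whereas the limits leave the step for methoxy on an aromatic carbon unreadable. Nothing measured here accounts for this shift.

The compounds shown leave open whether an amine or a methoxy on this carbon would keep the number high or lower it as fluoro does. They also leave open whether the aromatic methoxy would make any difference once fluoro is present.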